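This account rests on a few compounds, and the source may have more. Where it says the series, first, only, none or still open, it means among the compounds named here.

Measured so far in a functional assay on KB cells (Homo sapiens) for inhibition, read by MTT assay, with a stated time of 24 h, tested at 1 ug/mL; on this read-out higher numbers stand for more inhibition of growth at the one concentration tested and lower numbers for less inhibition of growth:
compound 1 `O=C(CCCCC(S)CCS)Nc1ccccc1` gives 11.6%
compound 2 `O=C(CCCCC(S)CCS)Nc1ccc(Cl)cc1` gives 13.4%
compound 3 `O=C(CCCCC(S)CCS)Nc1ccc(OC(F)(F)F)cc1` gives 6%

Compound 3, with 6% as its number, sits within the scatter of both other compounds, so no order among the three can be claimed. The next compound to be read is compound 4 `COc1ccc(NC(=O)CCCCC(S)CCS)cc1` and it differs from compound 3 by methyl in place of trifluoromethyl on an oxygen on an aromatic ring (methyl in place of trifluoromethyl on an oxygen on an aromatic ring, which reads as trifluoromethoxy to methoxy).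

Within the data shown here, no measured step makes this exchange directly. Two measured steps involve the trifluoromethoxy group, namely a number 5.6 percentage points lower from compound 1 to compound 3 (within the scatter) and also a number 7.4 percentage points lower from compound 2 to compound 3 (within the scatter) and neither leaves the scatter. The remaining step, a number 1.8 percentage points higher from compound 1 to compound 2 (within the scatter) (chloro in place of hydrogen), is equally small. Among the measured compounds shown here, every exchange measured so far stays within the scatter, and no compound goes against that, so no step beyond the scatter is expected here. The expected step is a number 4 percentage points higher from compound 3 to compound 4 (within the scatter) and this estimate carries no claim of a real difference. For compound 4 the estimated value is 10% with 3% to 18% as the expected range.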

Compound 4, percent growth inhibition at one concentration: 2.49%
For compound 4 the middle estimate is 7.5 percentage points above the measured one; the measured number lies below the stated range.
By their numbers in this assay, from the lowest: compounds 4, 3, 1 and 2 (each within the scatter of the next, the first and the last beyond it).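

In this assay the series now holds its first step beyond the scatter, a number 10.9 percentage points lower from compound 2 to compound 4 (beyond the scatter), a modest one, so an exchange on this aromatic carbon can separate two compounds, here methoxy in place of chloro. Among these compounds, that separation does not extend to the other exchanges: methoxy in place of hydrogen gives a number 9.1 percentage points lower from compound 1 to compound 4 (within the scatter) and methyl in place of trifluoromethyl on the oxygen gives a number 3.5 percentage points lower from compound 3 to compound 4 (within the scatter) and both stay inside the scatter, leaving methoxy not separable from hydrogen or from trifluoromethoxy, with the single pair of compound 2 and compound 4 as the only separated one. Nothing available on these compounds offers an explanation for that one separated pair.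

Open, going by these compounds, is whether an amine, a carboxylic acid or a nitrile on the same aromatic carbon, or a longer chain in place of methyl on the oxygen, would leave the scatter when set against compound 1. Among the compounds shown here, also open is how the separated pair behaves at any concentration other than the one tested, and whether it holds for a different chain on the carbonyl than the one all four compounds share.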